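The compounds below may be only part of what the source reports. "The series", "measured", "known", "first", "only" and "open" are said of these compounds alone.

In an ADME assay on HepG2 cells (Homo sapiens) for cytotoxicity, read by MTT assay, with a stated time of 72 h (a higher number here means that more compound is tolerated, a lower number that less compound is tolerated), compound 1 (`CC(C)Nc1nc2cc(-c3ccc(Br)cc3)sc2c(=O)[nH]1`) gives 13400 nM and compound 2 (`CC(C)(C)Nc1nc2ccsc2c(=O)[nH]1`) gives 8400 nM while compound 3 (`Cc1ccc(-c2csc3c(=O)[nH]c(NC(C)(C)C)nc23)cc1`) gives 1400 nM as the lowest of the three numbers, beyond the scatter of both others. Compound 4 (`CC(C)(C)Nc1nc2c(-c3ccc(F)cc3)csc2c(=O)[nH]1`) has fluoro in place of methyl on an aromatic carbon. Among the measured compounds shown here, the one measured step that bears on this is a 6.0-fold lower number from compound 2 to compound 3 (0.78 log units; beyond the scatter) in which 4-methylphenyl took the place of hydrogen on an aromatic carbon. That step was modest yet beyond the scatter, but it introduced the ring itself, whereas the new change leaves the ring in place and exchanges only its substituent. For the measured compounds named here, no measured pair exchanges methyl for fluoro, so the data give no direction for it. Hence no step beyond the scatter is expected in this assay and the estimated step is a 1.4-fold higher number from compound 3 to compound 4 (0.15 log units; within the scatter) at the middle of the range. Compound 4 is expected to give 2000 nM in this estimate, with a range of 800 nM to 6000 nM around it.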

Compound 4, half-maximal cytotoxic concentration: 2300 nM
Compound 4: middle estimate off by 1.2-fold (0.06 log units), on the low side; measured number inside the range.
By their numbers in this assay, from the lowest: compounds 3 and 4 (each within the scatter of the next); then compounds 2 and 1 (each within the scatter of the next).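

In this assay, exchanging the methyl of the 4-methylphenyl group for fluoro gives a 1.6-fold higher number from compound 3 to compound 4 (0.22 log units; within the scatter), so compounds 3 and 4 cannot be told apart by this substituent. Set against hydrogen, the 4-fluorophenyl group gives a 3.7-fold lower number from compound 2 to compound 4 (0.56 log units; beyond the scatter), which, alongside a 6.0-fold lower number from compound 2 to compound 3 (0.78 log units; beyond the scatter), shows that both aryl-bearing compounds with this substitution give lower numbers than compound 2, whichever of these two substituents the ring carries. Nothing measured here accounts for either step.

Going by these compounds, it remains open whether an unsubstituted phenyl group, or a phenyl group carrying an amine or a carboxylic acid in place of fluoro, would stay with compounds 3 and 4 or come closer to compound 2. Compound 1 differs from these compounds in more than one place, so it cannot settle the question.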